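Halogen swap on a weak cytotoxic thiocarbamate

The source may report more compounds than this note shows. Statements on the series, on what has been measured and on what is new or still open speak of the compounds shown alone.

Measured compounds:
compound 1, `O=C(CSC(=S)N[C@H]1CCOC1=O)Nc1ccc(Br)cc1`, 66500 nM
compound 2, `O=C(CSC(=S)N[C@H]1CCOC1=O)Nc1cccc(C(F)(F)F)c1`, 3130 nM

Of the compounds shown here, two sharing one core have been tested in a functional assay on MCF7 cells (Homo sapiens) for cytotoxicity, read by MTT assay, with a stated time of 72 h; on this read-out higher numbers stand for weaker inhibition and lower numbers for stronger inhibition. Compound 1 gives 66500 nM, the higher of the two numbers. Compound 2 gives 3130 nM, a gap from compound 1 that lies well beyond the usual scatter. Compound 1 therefore stands as the weaker of the two on this read-out; the two differ in more than one place, so only the two values themselves can be compared.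

Compound 3, `O=C(CSC(=S)N[C@H]1CCOC1=O)Nc1ccc(F)cc1`, has not yet been measured. It differs from compound 1 by fluoro in place of bromo on an aromatic carbon; that is, fluoro in place of bromo on an aromatic carbon, para to a large group. Among the measured compounds shown here, no measured pair in this set shows this change, so the size of the step rests on judgement alone. Compound 1 is already weak, and a single halogen exchange at this position is expected to move the number little, so compound 3 is expected to give a step of a 1.3-fold higher number from compound 1 to compound 3 (0.11 log units; within the scatter) that stays within or only slightly beyond the scatter, toward a weaker number. Compound 3 is estimated at 85000 nM, with a range from 25000 nM to 250000 nM.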

Compound 3, half-maximal inhibitory concentration: 5830 nM
Beside the measured number, compound 3's estimate is 15-fold (1.16 log units) above it; measured number outside the range, below it.
By their numbers in this assay, from the lowest: compounds 2 and 3 (each within the scatter of the next); then compound 1.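

Exchanging bromo for fluoro on this aromatic carbon, para to a large group, gives an 11-fold lower number from compound 1 to compound 3 (1.06 log units; beyond the scatter) in this assay, a large step that lies beyond the scatter. Among the compounds shown here, this is the first pair here to differ in one place only, which the two earlier compounds could not offer, and it shows that this position is not indifferent to which halogen it carries: one heavy atom exchanged for one heavy atom, with no ring, hydrogen-bond donor, hydrogen-bond acceptor or net charge entering or leaving, is enough to turn the high number of compound 1 into a far lower one. Nothing measured on these compounds bears on the size of this step, so the numbers alone describe it and offer no account of it.

With only bromo and fluoro compared at this place, the compounds shown do not tell whether chloro or iodo would fall in line with either of them, or how the number would respond to a non-halogen group such as methoxy or an amine. They also leave open whether the same exchange would give a step of similar size on a changed version of the shared core.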